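The source may report more compounds than this note shows. Statements on the series, on what has been measured and on what is new or still open speak of the compounds shown alone.

The three measured compounds share one core: compound 1 `CNc1nc(Nc2ccc(C)c(N)c2)ncc1C(=O)Nc1cc(NC(=O)c2cccc(C(F)(F)F)c2)ccc1C`, compound 2 `CNc1nc(Nc2ccc(C)c([N+](=O)[O-])c2)ncc1C(=O)Nc1cc(NC(=O)c2cc(OC)cc(OC)c2)ccc1C` and compound 3 `CNc1nc(Nc2ccc(C)c(N)c2)ncc1C(=O)Nc1cc(NC(=O)c2ccc(OC)cc2)ccc1C`. In a functional assay on K562 cells (Homo sapiens) for antiproliferative activity, read by CellTiter-Glo and CCK-8 assay, with a stated time of 72 h (on this read-out lower numbers stand for stronger inhibition of growth and higher numbers for weaker inhibition of growth), compound 1 gives 14 nM, compound 2 gives 1070 nM and compound 3 gives 610 nM. Compound 3 thus stands second highest of the three numbers; its value and that of compound 2 lie within the scatter of each other, whereas the step of a 44-fold higher number from compound 1 to compound 3 (1.64 log units; beyond the scatter) is large. Compound 4 `CNc1nc(Nc2ccc(C)c(N)c2)ncc1C(=O)Nc1cc(NC(=O)c2cc(OC)cc(OC)c2)ccc1C` differs from compound 3 by 3,5-dimethoxyphenyl in place of 4-methoxyphenyl on a carbonyl carbon. Within the data shown here, no measured step covers exactly this exchange; the only step in the set, a 44-fold higher number from compound 1 to compound 3 (1.64 log units; beyond the scatter), concerns a different group on the same carbonyl carbon and so bears on it only loosely. Compound 2 carries the same 3,5-dimethoxyphenyl as compound 4 but differs from it elsewhere, and its value sits within the scatter of compound 3. The step of a 1.3-fold higher number from compound 3 to compound 4 (0.12 log units; within the scatter) is therefore expected to stay within the scatter. The estimate for compound 4 in this assay is 800 nM, with a range from 300 nM to 2500 nM.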

Compound 4, concentration for 50% growth inhibition: 230 nM
Estimate against measurement, compound 4: 3.5-fold (0.54 log units) above, and the stated range ends above it.
By their numbers in this assay, from the lowest: compound 1; then compound 4; then compounds 3 and 2 (each within the scatter of the next).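

In this assay, the exchange on the carbonyl carbon can now be read directly: the step of a 2.7-fold lower number from compound 3 to compound 4 (0.42 log units; beyond the scatter) shows that 3,5-dimethoxyphenyl and 4-methoxyphenyl are not equivalent here, while the step of a 16-fold higher number from compound 1 to compound 4 (1.22 log units; beyond the scatter) keeps 3-(trifluoromethyl)phenyl clearly ahead of 3,5-dimethoxyphenyl. Among these compounds, with 3,5-dimethoxyphenyl held constant, the step of a 4.7-fold lower number from compound 2 to compound 4 (0.67 log units; beyond the scatter) gives the first reading at a second place, amino in place of nitro on an aromatic carbon. Nothing available accounts for either change.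

The compounds shown leave open how a nitrile or a carboxylic acid on the phenyl ring of this carbonyl group would compare with trifluoromethyl. They also leave open whether amino in place of nitro gives a similar step when 3-(trifluoromethyl)phenyl sits on the carbonyl carbon.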